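Piperazine dithiocarbamate series: acetyl and hydroxy variations

The source may report more compounds than this note shows. Statements on the series, on what has been measured and on what is new or still open speak of the compounds shown alone.

Compound 1 `CCN1CCN(C(=S)SCC(=O)N(Cc2ccc(OC)cc2)c2cc(OC)c(OC)c(OC)c2)CC1` is the starting point of this set; in a functional assay on MGC-803 cells (Homo sapiens) for inhibition, read by CCK-8 assay, with a stated time of 48 h (a higher number here means a weaker inhibitor, a lower number a stronger inhibitor), compound 1 gives 9890 nM. Compound 2 `COc1ccc(CN(C(=O)CSC(=S)N2CCN(C(C)=O)CC2)c2cc(OC)c(OC)c(OC)c2)cc1` carries the change acetyl in place of ethyl on an amine nitrogen in a ring and in this assay compound 2 gives 480 nM, so the step is a 21-fold lower number from compound 1 to compound 2 (1.31 log units; beyond the scatter). Compound 3 `CCN1CCN(C(=S)SCC(=O)N(Cc2ccc(OC)c(O)c2)c2cc(OC)c(OC)c(OC)c2)CC1` differs from compound 1 by hydroxy in place of hydrogen on an aromatic carbon; in this assay compound 3 gives 380 nM, a step of a 26-fold lower number from compound 1 to compound 3 (1.42 log units; beyond the scatter). The values of compound 2 and compound 3 lie within the scatter of each other, so no order between them is drawn.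

Compound 4 `COc1ccc(CN(C(=O)CSC(=S)N2CCN(C(C)=O)CC2)c2cc(OC)c(OC)c(OC)c2)cc1O`, not yet measured, differs from compound 3 by acetyl in place of ethyl on an amine nitrogen in a ring. Among the measured compounds shown here, this is the same change as the one from compound 1 to compound 2, with the same surroundings at the place, and the core of compound 3 differs from the core of compound 1 by the hydroxy already noted. The earlier instance of the change gave a 21-fold lower number from compound 1 to compound 2 (1.31 log units; beyond the scatter). Whether the same size recurs on the core of compound 3 is open: compound 2 and compound 3 each gained much from one change, yet ended near each other, which leaves it unclear how far the two gains combine. A smaller step is therefore expected here, estimated as a 3.2-fold lower number from compound 3 to compound 4 (0.50 log units; beyond the scatter), resting on compound 3 at 380 nM and on the earlier step of a 21-fold lower number from compound 1 to compound 2 (1.31 log units; beyond the scatter). For compound 4 in this assay the expected value is 120 nM, with a likely range from 25 nM to 600 nM.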

Compound 4, half-maximal inhibitory concentration: 310 nM
Compound 4: the middle estimate sits 2.6-fold (0.41 log units) below what was measured; the measured number falls inside the stated range.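

In this assay, acetyl in place of ethyl on the ring nitrogen gives a 1.2-fold lower number from compound 3 to compound 4 (0.09 log units; within the scatter), so the large step seen on the core of compound 1 does not carry over to the core of compound 3: the same change on two cores in this assay, a 21-fold lower number (1.31 log units; beyond the scatter) from compound 1 to compound 2 and a 1.2-fold lower number (0.09 log units; within the scatter) from compound 3 to compound 4, 17-fold (1.23 log units) apart, beyond the scatter of two such steps

The hydroxy change behaves in the same way, giving a 1.5-fold lower number from compound 2 to compound 4 (0.19 log units; within the scatter) on the core of compound 2, far from its step on the core of compound 1: the same change on two cores in this assay, a 26-fold lower number (1.42 log units; beyond the scatter) from compound 1 to compound 3 and a 1.5-fold lower number (0.19 log units; within the scatter) from compound 2 to compound 4, 17-fold (1.23 log units) apart, beyond the scatter of two such steps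

Within these four compounds, each change is therefore large on the core of compound 1 and within the scatter once the other change is present, so the two gains do not add, but a single set of four compounds shows neither why this happens nor whether it holds elsewhere in the series.

Among the compounds shown here, it remains open whether other groups on the ring nitrogen, such as a propionyl group, a methylsulfonyl group or a chain ending in a carboxylic acid, would also show no step on the hydroxy core. On these data alone, it is equally open whether an amine or a fluorine in place of the hydroxy would meet the same result, or whether any such group would move the number beyond the scatter of compound 2, compound 3 and compound 4.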